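This account rests on a few compounds, and the source may have more. Where it says the series, first, only, none or still open, it means among the compounds named here.

Measured in an ADME assay on L929 cells (Mus musculus) for cytotoxicity, read by resazurin assay, with a stated time of 48 h; on this read-out lower numbers stand for higher toxicity in this test and higher numbers for lower toxicity in this test:
- Compound 1 `COC(=O)CCn1c2ccc([N+](=O)[O-])cc2c(=O)n1Cc1ccccc1`: > 256000 nM
- Compound 2 `CCOC(=O)CCCn1c2ccc([N+](=O)[O-])cc2c(=O)n1Cc1ccccc1`: 78100 nM
- Compound 3 `CCOCCCn1c2ccc([N+](=O)[O-])cc2c(=O)n1Cc1ccccc1`: 170000 nM

The entry for compound 1 is a limit of the assay, not a number. Compound 3, at 170000 nM, holds the higher of the two true numbers, and the gap is a 2.2-fold higher number from compound 2 to compound 3 (0.34 log units; beyond the scatter).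

Compound 4 `O=C(OCc1ccccc1)n1c2ccc([N+](=O)[O-])cc2c(=O)n1Cc1ccccc1` differs from compound 3 by benzyloxycarbonyl in place of 3-ethoxypropyl on an aromatic nitrogen. The nearest measured changes are an at least 3.2-fold lower number from compound 1 to compound 2 (0.51 log units; beyond the scatter), an at least 1.5-fold lower number from compound 1 to compound 3 (0.17 log units; that floor lies within the scatter) and a 2.2-fold higher number from compound 2 to compound 3 (0.34 log units; beyond the scatter). All of them alter only the chain, and their directions are mixed, so the guidance is loose. A modestly lower number is expected, namely a 2.4-fold lower number from compound 3 to compound 4 (0.39 log units; beyond the scatter). For compound 4 the estimated value is 70000 nM, with an expected range of 15000 nM to 250000 nM.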

Compound 4, concentration lethal to 50% of the cells: 86100 nM
Compound 4: the middle estimate sits 1.2-fold (0.09 log units) below what was measured; the range from low to high includes it.
By their numbers in this assay, from the lowest: compounds 2, 4 and 3 (each within the scatter of the next, the first and the last beyond it). At a limit, above all of these: compound 1.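

Where the earlier compounds varied only a chain on this aromatic nitrogen, compound 4 carries benzyloxycarbonyl there, with its six-membered aromatic ring of carbon only, and in this assay this change gives a 2.0-fold lower number from compound 3 to compound 4 (0.30 log units; within the scatter) and a 1.1-fold higher number from compound 2 to compound 4 (0.04 log units; within the scatter), so it stands apart from neither chain. The remaining step reads an at least 2.9-fold lower number from compound 1 to compound 4 (0.47 log units; beyond the scatter). Its starting entry, for compound 1, is a limit of the assay and not a number: the limit of > 256000 nM in this assay, at which 1 of the 4 values shown sits.

The compounds shown leave open what an amine or a carboxylic acid at this position would give. They also leave open whether a longer chain would differ beyond the scatter.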